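Replacing the benzylic aryl group on the imidazole core

The source may hold more compounds than are shown below. What is called first, only, known or untested is meant among the compounds shown, and "the series" means these compounds.

compound 1: `Cc1ccccc1Cc1cnc(CCc2ccc(-c3ccccc3C(=O)O)cc2)[nH]1`, 127 nM 
compound 2: `O=C(O)c1ccccc1-c1ccc(CCc2ncc(Cc3ccc(Cl)cc3)[nH]2)cc1`, 2290 nM 

In an in vitro functional assay on cells for agonist activity at Bombesin receptor subtype-3 (Homo sapiens), read by luminescence and calcium flux (on this read-out higher numbers stand for an effect only at larger amounts of compound and lower numbers for an effect already at smaller amounts), compound 2 gives the highest number of the two measured compounds; the step of an 18-fold higher number from compound 1 to compound 2 (1.26 log units; beyond the scatter) is beyond the scatter. Compound 3 `CC(C)(C)Cc1cnc(CCc2ccc(-c3ccccc3C(=O)O)cc2)[nH]1` is not yet measured; it differs from compound 2 by tert-butyl in place of 4-chlorophenyl on a saturated chain carbon bound to an aromatic carbon. Within the data shown here, the single measured step, an 18-fold higher number from compound 1 to compound 2 (1.26 log units; beyond the scatter), shows that the group at this saturated chain carbon moves the number strongly, but no measured pair shows an aryl swapped for an alkyl group here, so direction cannot be read from the data. For compound 3 the expected step is a 1.3-fold lower number from compound 2 to compound 3 (0.10 log units; within the scatter), with wide uncertainty. The estimate for compound 3 is 1800 nM, range 400 nM to 8000 nM.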

Compound 3, half-maximal effective concentration: 106 nM
For compound 3 the middle estimate is 17-fold (1.23 log units) above the measured one, and the stated range ends above it.
By their numbers in this assay, from the lowest: compounds 3 and 1 (each within the scatter of the next); then compound 2.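

Tert-butyl in place of 4-chlorophenyl on a saturated chain carbon bound to an aromatic carbon gives a 22-fold lower number from compound 2 to compound 3 (1.33 log units; beyond the scatter), so a low number at this place does not need an aromatic ring. Tert-butyl in place of 2-methylphenyl gives a 1.2-fold lower number from compound 1 to compound 3 (0.08 log units; within the scatter), which leaves 4-chlorophenyl as the only one of the three groups shown with a high number. Nothing at hand explains either step.

As far as these compounds go, whether a cyclohexyl group or an amine at this place also keeps the number low remains open. So does whether the chlorine atom or its place on the ring sets the high number of compound 2.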